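This account rests on a few compounds, and the source may have more. Where it says the series, first, only, none or still open, it means among the compounds named here.

Measured compounds:
compound 1 `CC1(C)[C@H]2CC[C@]1(C)N(Cc1cn(-c3ccc(Cl)cc3)nn1)C(=O)C2` — 160 nM
compound 2 `CC1(C)[C@H]2CC[C@]1(C)N(Cc1cn(-c3ccccc3O)nn1)C(=O)C2` — 540 nM
compound 3 `CC1(C)[C@H]2CC[C@]1(C)N(Cc1cn(-c3ccccc3)nn1)C(=O)C2` — 50 nM

These three compounds were tested in a functional assay on LoVo cells (Homo sapiens) for inhibition, read by MTT assay, with a stated time of 24 h; a higher number here means a weaker inhibitor, a lower number a stronger inhibitor. Compound 1 stands second highest of the three numbers: compound 3 sits beneath it by a 3.2-fold lower number from compound 1 to compound 3 (0.51 log units; beyond the scatter), and compound 2 above it by a 3.4-fold higher number from compound 1 to compound 2 (0.53 log units; beyond the scatter). The unmeasured compound 4 `COc1cccc(-n2cc(CN3C(=O)C[C@@H]4CC[C@@]3(C)C4(C)C)nn2)c1` differs from compound 1 in one place: 3-methoxyphenyl in place of 4-chlorophenyl on an aromatic nitrogen.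

For the measured compounds named here, two measured steps bear on this change, since both swap the group on the same aromatic nitrogen. Removing the chloro gave a 3.2-fold lower number from compound 1 to compound 3 (0.51 log units; beyond the scatter), and replacing the 4-chlorophenyl by 2-hydroxyphenyl gave a 3.4-fold higher number from compound 1 to compound 2 (0.53 log units; beyond the scatter); between those two, hydrogen in place of hydroxy gave an 11-fold lower number from compound 2 to compound 3 (1.03 log units; beyond the scatter). Every substituted phenyl so far gives a higher number than the plain phenyl of compound 3, and the 3-methoxyphenyl is another substituted phenyl. A modest rise or no change beyond the scatter is therefore expected for compound 4, giving an estimated step of a 1.3-fold higher number from compound 1 to compound 4 (0.10 log units; within the scatter). Compound 4 is estimated at 200 nM, with a range from 70 nM to 600 nM.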

Compound 4, half-maximal inhibitory concentration: 80 nM
Estimate against measurement, compound 4: 2.5-fold (0.40 log units) above; the measured number falls inside the stated range.
By their numbers in this assay, from the lowest: compounds 3, 4 and 1 (each within the scatter of the next, the first and the last beyond it); then compound 2.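

On this aromatic nitrogen, a substituted phenyl no longer always sits clearly apart from the plain phenyl: adding methoxy gave a 1.6-fold higher number from compound 3 to compound 4 (0.20 log units; within the scatter) and so cannot be told from no substituent here. Compound 4 also cannot be separated from the 4-chlorophenyl compound, with a 2.0-fold lower number from compound 1 to compound 4 (0.30 log units; within the scatter) as the step between them. Only the comparison with the 2-hydroxyphenyl compound gives a clear difference, with a 6.8-fold lower number from compound 2 to compound 4 (0.83 log units; beyond the scatter) as the step, so having a substituent does not by itself set the number, and compound 2 stays apart from compound 4.

Still open, from the compounds shown here alone, is whether a 4-methoxyphenyl or a 3-chlorophenyl would match compound 4, and what an amine or a carboxylic acid on this phenyl would do. No measurement here explains why these groups differ.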